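This account rests on a few compounds, and the source may have more. Where it says the series, first, only, none or still open, it means among the compounds named here.

Measured in an ADME assay on HepG2 2.2.15 cells (Homo sapiens) for cytotoxicity, read by luminescence, with a stated time of 3 days; on this read-out higher numbers stand for lower toxicity in this test and lower numbers for higher toxicity in this test:
- compound 1 `O=C(Nc1ccc(F)c(Cl)c1)c1ccc(F)c(S(=O)(=O)N2C[C@H](O)CC[C@H](O)C2)c1`: 25500 nM
- compound 2 `O=C(Nc1ccc(F)c(Cl)c1)c1ccc(F)c(S(=O)(=O)N2CCSCC(O)C2)c1`: 19000 nM
- compound 3 `O=C(Nc1ccc(F)c(Cl)c1)c1ccc(F)c(S(=O)(=O)N2CCCCCCC2O)c1`: 7000 nM

Compound 3 stands lowest of the three, beyond the scatter from both others. Compound 4 `O=C(Nc1ccc(F)c(Cl)c1)c1ccc(F)c(S(=O)(=O)N2CCCCC(CO)C2)c1` differs from it by a group of 9 heavy atoms (7 carbon, 1 nitrogen, 1 oxygen; one seven-membered non-aromatic ring with 1 hetero atom) in place of a group of 9 heavy atoms (7 carbon, 1 nitrogen, 1 oxygen; one eight-membered non-aromatic ring with 1 hetero atom), on a sulfonyl sulfur, with 3-(hydroxymethyl)azepan-1-yl on the sulfonyl sulfur. Within the data shown here, no measured step makes this exact change. Two come nearest, both modest: a 3.6-fold lower number from compound 1 to compound 3 (0.56 log units; beyond the scatter) and a 2.7-fold lower number from compound 2 to compound 3 (0.43 log units; beyond the scatter). Each goes from a seven-membered ring to an eight-membered one, the reverse direction, though other atoms change too. The remaining step, a 1.3-fold lower number from compound 1 to compound 2 (0.13 log units; within the scatter), lies within the scatter. A small upward move in this assay is therefore expected, an estimated 1.9-fold higher number from compound 3 to compound 4 (0.27 log units; within the scatter). For compound 4 the estimate is 13000 nM, with an expected range of 5000 nM to 30000 nM.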

Compound 4, half-maximal cytotoxic concentration: 3100 nM
Compound 4: the middle estimate sits 4.2-fold (0.62 log units) above what was measured; measured number below the stated range.
By their numbers in this assay, from the lowest: compound 4; then compound 3; then compounds 2 and 1 (each within the scatter of the next).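

In this assay, among these compounds, a 2.3-fold lower number from compound 3 to compound 4 (0.35 log units; beyond the scatter) runs against the earlier steps, where compound 1 and compound 2, with seven-membered rings, stood above the eight-membered compound 3, so ring size alone does not order the numbers on this sulfonyl sulfur. Within the seven-membered rings, 3-(hydroxymethyl)azepan-1-yl also gives a 6.1-fold lower number from compound 2 to compound 4 (0.79 log units; beyond the scatter) and an 8.2-fold lower number from compound 1 to compound 4 (0.92 log units; beyond the scatter), the largest step in the set. Nothing measured here accounts for these steps.

Whether the hydroxymethyl group itself matters remains open, as the unsubstituted azepan-1-yl is not among the compounds shown. As far as these compounds go, how an aminomethyl or carboxylic acid group would compare at that place is also open.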